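A mirror image of compound 2 in mice

The source may report more compounds than this note shows. Statements on the series, on what has been measured and on what is new or still open speak of the compounds shown alone.

- Compound 1 `CN(CCCNC(=O)Nc1ccc(C(C)(C)C)cc1)C[C@H]1C[C@@H](c2ccc3c(N)ncnn23)[C@H](O)[C@@H]1O`: 3020 ng.h/mL
- Compound 2 `CC(C)NC[C@@H]1C[C@H](c2ccc3c(N)ncnn23)[C@@H](O)[C@H]1O`: 7170 ng.h/mL

In an ADME assay on the whole organism (Mus musculus, strain BALB/c) for pharmacokinetics, read by LC-MS, with a stated time of 600 min, at a dose of 20 mg/kg by the intravenous route (a higher number here means more compound in the circulation at the dose given, a lower number less compound in the circulation), compound 2 gives 7170 ng.h/mL, the higher of the two numbers, and its gap to compound 1 lies beyond the usual scatter.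

The next compound to consider is compound 3 `CC(C)NC[C@H]1C[C@@H](c2ccc3c(N)ncnn23)[C@H](O)[C@@H]1O`, which relates to compound 2 as follows: the two compounds have the same atoms and bonds and differ only in configuration as drawn: 4 of 4 stereo elements differ (all stereocentres are inverted: mirror images); a stereocentre at a saturated ring carbon is drawn S in compound 2 and R in compound 3; a stereocentre at a saturated ring carbon is drawn R in compound 2 and S in compound 3; a stereocentre at a saturated ring carbon is drawn R in compound 2 and S in compound 3; a stereocentre at a saturated ring carbon is drawn S in compound 2 and R in compound 3. Nothing is added or removed, so the two are mirror images. Among the compounds with values here, no measured pair of mirror images is available to show how far such a change can move the number in this assay. A small downward step, within the scatter, is therefore expected, though with wide uncertainty. The estimated change is a 1.3-fold lower number from compound 2 to compound 3 (0.12 log units; within the scatter). Compound 3 is expected to give 5500 ng.h/mL, with an estimated range of 2400 ng.h/mL to 12000 ng.h/mL.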

Compound 3, area under the concentration-time curve: 14200 ng.h/mL
Estimate against measurement, compound 3: 2.6-fold (0.41 log units) below, and the stated range ends below it.
By their numbers in this assay, from the lowest: compound 1; then compounds 2 and 3 (each within the scatter of the next).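

Inverting all four stereocentres together gives a 2.0-fold higher number from compound 2 to compound 3 (0.30 log units; within the scatter) in this assay. Within the data shown here, this pair is the first measured view of what a mirror-image change can do to the number, and a step of this size does not separate the two compounds. With nothing entering or leaving, the comparison isolates a single kind of change, and its reading rests on one fact: the fact that compounds 2 and 3 differ only in the configuration as drawn

The compounds shown leave open whether inverting the stereocentres one at a time would give a step of a different size. They also leave open whether the two mirror images would stay within the scatter of each other if a carboxylic acid took the place of the isopropyl amine.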